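Adding dimethylamino to the phenyl ring of compound 3

This account rests on a few compounds, and the source may have more. Where it says the series, first, only, none or still open, it means among the compounds named here.

- Compound 1 `C=C1C(=O)O[C@H]2CC3=C[C@H](C/C(C)=C/[C@@H](OC(=O)c4ccc(C(F)(F)F)cc4)[C@H]12)OC3=O`: > 10000 nM, a limit of the assay
- Compound 2 `C=C1C(=O)O[C@H]2CC3=C[C@H](C/C(C)=C/[C@@H](OC(=O)c4ccc(C(C)=O)cc4)[C@H]12)OC3=O`: 2300 nM
- Compound 3 `C=C1C(=O)O[C@H]2CC3=C[C@H](C/C(C)=C/[C@@H](OC(=O)/C=C/c4ccccc4)[C@H]12)OC3=O`: 4800 nM

In a functional assay on A549 cells (Homo sapiens) for cytotoxicity, read by MTT assay, with a stated time of 48 h (a lower number here means a stronger inhibitor, a higher number a weaker inhibitor), compound 3 gives 4800 nM, the higher of the two actual numbers. The gap to its nearest neighbour is a 2.1-fold higher number from compound 2 to compound 3 (0.32 log units; beyond the scatter). Compound 4 `C=C1C(=O)O[C@H]2CC3=C[C@H](C/C(C)=C/[C@@H](OC(=O)/C=C/c4ccc(N(C)C)cc4)[C@H]12)OC3=O` has dimethylamino in place of hydrogen on an aromatic carbon, para to a large group: dimethylamino in place of hydrogen on an aromatic carbon. Among the compounds with values here, no measured step makes this exact change. The closest is the swap of one substituent on an aromatic carbon, an at least 4.3-fold lower number from compound 1 to compound 2 (0.63 log units; beyond the scatter), which shows that such a swap can move the number, though on a different ester group and measured against a limit. The ester change an at least 2.0-fold lower number from compound 1 to compound 3 (0.31 log units; beyond the scatter) is also at least modest. A modest shift in this assay therefore seems reasonable, with only a tentative lean towards a lower number. The expected step is a 1.4-fold lower number from compound 3 to compound 4 (0.14 log units; within the scatter). For compound 4 the estimated value is 3500 nM, with an expected range from 1200 nM to 10000 nM.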

Compound 4, half-maximal inhibitory concentration: > 10000 nM
Compound 4 ended at the assay's limit; the forecaster's own chance of this, stated with the estimate: 12%; middle value at least 2.8-fold (0.45 log units) away from the limit.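

In this assay, dimethylamino in place of hydrogen on the aromatic carbon para to a large group gives an at least 2.0-fold higher number from compound 3 to compound 4 (0.31 log units; beyond the scatter), so this position on the 2-phenylethenyl ester is sensitive to the change, and the shift runs towards weaker inhibition. Compound 2 also keeps a clear lead over the new compound, with an at least 4.3-fold higher number from compound 2 to compound 4 (0.63 log units; beyond the scatter). Compound 4, like compound 1, stands at a limit of the assay, so the step between those two cannot be read, and both of these compounds sit at the same ceiling: the limit of > 10000 nM in this assay, at which 2 of the 4 values shown sit.

As far as these compounds go, how far compound 4 lies past that limit stays open, and with it the true size of both readable steps. The compounds shown also do not tell whether a methoxy group, a fluorine atom or a primary amine at this position would move the number in the same direction.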